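A few compounds are considered here, and "the series" means these few. Any claim that something is new, unique, unknown or untested is made for them only; others in the source may bear on it.

Measured compounds:
- compound 1, `CCOc1cccc(C(CC)c2ccc(O)c(OC)c2)c1O`: 13700 nM
- compound 2, `CCC(c1ccc(O)c(OC)c1)c1ccc(O)cc1O`: 15300 nM

In a functional assay, with a stated time of 40 min (a higher number here means a weaker inhibitor, a lower number a stronger inhibitor), compound 1 gives 13700 nM, the lower of the two numbers in hand, while compound 2 gives 15300 nM, a number that sits within the scatter of compound 1, so the two are not told apart. Among the measured compounds shown here, compound 1 thus stands on a close pair with no measured step to guide a prediction.

The unmeasured compound 3, `CCC(c1ccc(O)c(OC)c1)c1cccc(C(C)C)c1O`, differs from compound 1 in one place: isopropyl in place of ethoxy on an aromatic carbon. For the measured compounds named here, no step of this kind has been measured among the compounds here, so what it does in this assay is open. He expects a shift of a 1.1-fold lower number from compound 1 to compound 3 (0.06 log units; within the scatter), small enough to stay within the scatter, with no clear direction favoured. His estimate for compound 3 in this assay is 12000 nM, with a range from 5000 nM to 30000 nM.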

Compound 3, half-maximal inhibitory concentration: 10100 nM
Compound 3: the middle estimate sits 1.2-fold (0.07 log units) above what was measured, within the range that was stated.
By their numbers in this assay, from the lowest: compounds 3, 1 and 2 (each within the scatter of the next).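

In this assay the swap of isopropyl for ethoxy on the aromatic carbon ortho to a hydroxy group gives a 1.4-fold lower number from compound 1 to compound 3 (0.13 log units; within the scatter) and so does not tell compound 1 and compound 3 apart. At this position, then, ethoxy with its one hydrogen-bond acceptor can be replaced by isopropyl with none, at equal heavy-atom count, without a difference this assay can resolve. Nothing measured here explains why the two groups read alike.

Going by these compounds, whether a different kind of group at this position, such as an amine, a carboxylic acid or a longer chain, would move the number beyond the scatter stays open. So does whether removing the hydroxy group ortho to this position would leave the result unchanged.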